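From compound 3 to compound 4: one phenyl group exchanged

The compounds below may be only part of what the source reports. "The series", "measured", "known", "first", "only" and "open" are said of these compounds alone.

In a toxicity assay on CHO cells (Cricetulus griseus) for cytotoxicity, read by MTT assay (on this read-out lower numbers stand for stronger inhibition and higher numbers for weaker inhibition), compound 1 (`O=C(N/N=C/c1ccc(F)cc1)c1cn(C2CC2)c2cc(N3CCNCC3)c(F)cc2c1=O`) gives 25000 nM as its value. Compound 2 (`COc1ccc(/C=N/NC(=O)c2cn(C3CC3)c3cc(N4CCNCC4)c(F)cc3c2=O)cc1O`) gives 25000 nM on the same read-out. Compound 3 (`O=C(N/N=C/c1ccccc1O)c1cn(C2CC2)c2cc(N3CCNCC3)c(F)cc2c1=O`) gives 25000 nM as well, which places it level with the other two.

The next structure, compound 4 (`COc1ccc(/C=N/NC(=O)c2cn(C3CC3)c3cc(N4CCNCC4)c(F)cc3c2=O)cc1`), has 4-methoxyphenyl in place of 2-hydroxyphenyl on a carbon with a double bond to nitrogen.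

Three measured steps exchange the group at this same place: (no change at the digits printed from compound 1 to compound 2 (within the scatter)), (no change at the digits printed from compound 1 to compound 3 (within the scatter)) and (no change at the digits printed from compound 2 to compound 3 (within the scatter)). None of them shifted the value, across 4-fluorophenyl, 3-hydroxy-4-methoxyphenyl and 2-hydroxyphenyl. Among the compounds with values here, no measured compound yet carries 4-methoxyphenyl itself, so the evidence is indirect and rests on three compounds only.

In this assay the step expected for compound 4 is no change at the digits printed from compound 3 to compound 4 (within the scatter) and no direction is favoured. Estimated for compound 4: 25000 nM as the middle, with 12500 nM to 50000 nM as the expected range.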

Compound 4, half-maximal inhibitory concentration: 25000 nM
For compound 4 middle estimate and measured number coincide at the digits printed; low and high end bracket the measured number.
By their numbers in this assay, from the lowest: compounds 1, 2, 3 and 4 (each within the scatter of the next).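

In this assay, 4-methoxyphenyl in place of 2-hydroxyphenyl on a carbon with a double bond to nitrogen gives no change at the digits printed from compound 3 to compound 4 (within the scatter), so this exchange, which takes the group from 1 hydrogen-bond donor to 0, leaves the read-out untouched. The two single-substituent steps on the aromatic ring read the same way: hydrogen in place of hydroxy gives no change at the digits printed from compound 2 to compound 4 (within the scatter), and methoxy in place of fluoro gives no change at the digits printed from compound 1 to compound 4 (within the scatter). No measured data offer an explanation for this flat picture.

Within the data shown here, all the groups at this place so far are substituted phenyl rings, so a phenyl carrying an amine or a carboxylic acid remains an open case. Also open, going by these compounds, is whether a longer chain in place of the phenyl ring would leave the read-out equally unmoved.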